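Phenyl for methyl on a triazine inhibitor of protoporphyrinogen oxidase

This account rests on a few compounds, and the source may have more. Where it says the series, first, only, none or still open, it means among the compounds named here.

Measured compounds:
Compound 1 `CCNc1nc(NCC)nc(C(Cl)(Cl)Cl)n1`: 24000 nM
Compound 2 `CCNc1nc(C)nc(NCC)n1`: 18600 nM

In an assay on isolated protein (Scenedesmus acutus) for inhibition of protoporphyrinogen IX oxidase (Cichorium intybus) (on this read-out lower numbers stand for stronger inhibition and higher numbers for weaker inhibition), compound 1 gives 24000 nM and compound 2 gives 18600 nM. For the measured compounds named here, the one measured step, a 1.3-fold lower number from compound 1 to compound 2 (0.11 log units; within the scatter), is within the scatter, so compound 2 and compound 1 cannot be ordered on these numbers; compound 2 simply shows the lower of the two values, at a distance that repeated measurements would blur.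

Compound 3 `CCNc1nc(NCC)nc(-c2ccccc2)n1` has not yet been measured. It differs from compound 2 by phenyl in place of methyl on an aromatic carbon, on the aromatic carbon between two ring nitrogen atoms, meta to the two ethylamino groups and opposite the ring nitrogen. Going by the values given here, no measured step exchanges a methyl for a phenyl; the only step at hand, a 1.3-fold lower number from compound 1 to compound 2 (0.11 log units; within the scatter), concerns a different group at the same position and was within the scatter. There is therefore no shown basis for a change beyond the scatter in this assay, in either direction, and the expectation is widened by the lack of a comparable step.

The estimate for compound 3 in this assay is 15000 nM, with a range from 4000 nM to 60000 nM, which means an expected step of a 1.2-fold lower number from compound 2 to compound 3 (0.09 log units; within the scatter).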

Compound 3, half-maximal inhibitory concentration: 95500 nM
Beside the measured number, compound 3's estimate is 6.4-fold (0.80 log units) below it, and the stated range ends below it.
By their numbers in this assay, from the lowest: compounds 2 and 1 (each within the scatter of the next); then compound 3.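

In this assay this aromatic carbon proves sensitive to what it carries: phenyl in place of methyl gives a 5.1-fold higher number from compound 2 to compound 3 (0.71 log units; beyond the scatter) and phenyl in place of trichloromethyl gives a 4.0-fold higher number from compound 1 to compound 3 (0.60 log units; beyond the scatter) and both steps lie beyond the scatter, which the earlier step, a 1.3-fold lower number from compound 1 to compound 2 (0.11 log units; within the scatter), did not. Of the three groups, methyl and trichloromethyl cannot be told apart on these numbers, while phenyl, the only one with a six-membered aromatic ring, stands apart from both on the side of weaker inhibition, though only modestly. Nothing at hand bears on what lies behind this shift, so it stands as an observation alone.

From the compounds shown here alone, whether an amino group, a methoxy group or a plain hydrogen on this carbon would fall with methyl and trichloromethyl or with phenyl stays open, as does whether a cyclohexyl group would behave like phenyl. Going by these compounds, all three compounds carry the same two ethylamino groups, so it is also open whether the phenyl step would hold with longer chains there, such as propylamino groups.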